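A few compounds are considered here, and "the series" means these few. Any claim that something is new, unique, unknown or untested is made for them only; others in the source may bear on it.

Measured compounds:
- compound 1, `CC(C)(C)CC[C@H](c1ccc(C(=O)NCc2nn[nH]n2)cc1)N1C(=O)C(c2cccc(C(F)(F)F)c2)=N[C@]12CC[C@@H](C(C)(C)C)CC2` — 180 nM
- compound 2, `CC(C)(C)CC[C@H](c1ccc(C(=O)NCCS(=O)(=O)O)cc1)N1C(=O)C(c2cc(Cl)cc(Cl)c2)=N[C@]12CC[C@@H](C(C)(C)C)CC2` — 8500 nM
- compound 3, `CC(C)CC[C@H](c1ccc(C(=O)NCc2nn[nH]n2)cc1)N1C(=O)C(c2cc(Cl)cc(Cl)c2)=N[C@]12CC[C@@H](C(C)(C)C)CC2` — 150 nM

All three were tested in a functional assay on CHO cells for antagonist activity at Glucagon receptor (Homo sapiens), read by cAMP accumulation, with stated times of 30 min and 45 min; on this read-out higher numbers stand for weaker inhibition and lower numbers for stronger inhibition. Compound 2 stands at the highest number of the three, that is, the weakest inhibition; compound 1 and compound 3 both lie far below it, beyond the scatter, while those two are within the scatter of each other and differ from compound 2 at more than one place, so no single step can be read from them.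

Compound 4, `CC(C)(C)CC[C@H](c1ccc(C(=O)NCCCC(=O)O)cc1)N1C(=O)C(c2cc(Cl)cc(Cl)c2)=N[C@]12CC[C@@H](C(C)(C)C)CC2`, is not yet measured. It differs from compound 2 in one place only: carboxymethyl in place of sulfo on a saturated chain carbon, two bonds along the chain from an amide-type nitrogen. Among the compounds with values here, no step of this kind is among the measured pairs, so the expectation rests on the size of the gap that compound 2 shows to compound 1 and compound 3. A step from compound 2 to compound 4 of a 7.1-fold lower number from compound 2 to compound 4 (0.85 log units; beyond the scatter) is expected, toward stronger inhibition, beyond the scatter but leaving compound 4 short of compound 1 and compound 3. For compound 4 in this assay the estimate is 1200 nM, with a range from 250 nM to 6000 nM.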

Compound 4, half-maximal inhibitory concentration: 350 nM
The estimate for compound 4 lay 3.4-fold (0.54 log units) above the measured number; measured number inside the range.
By their numbers in this assay, from the lowest: compounds 3, 1 and 4 (each within the scatter of the next, the first and the last beyond it); then compound 2.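

In this assay, carboxymethyl in place of sulfo on a saturated chain carbon, two bonds along the chain from an amide-type nitrogen, gives a 24-fold lower number from compound 2 to compound 4 (1.39 log units; beyond the scatter), a large step beyond the scatter. The earlier compounds shown here each differed from compound 2 at more than one place, so their gaps could not be tied to any one position; this step shows that a change at this position alone is enough to move the number by a large amount. Nothing given here bears on why this exchange has such an effect.

The exchange alters both the end group and the chain, so the step does not separate the two. A carboxylic acid on the shorter (2-carboxyethyl)amino chain, a sulfo group on a longer chain, or an amine at the chain end would be needed to tell them apart.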